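A pyridin-3-yl group replaces methyl in compound 3

This account rests on a few compounds, and the source may have more. Where it says the series, first, only, none or still open, it means among the compounds named here.

The values below come from a functional assay on the whole organism with Mus musculus as the target (a lower number here means that less compound is needed, a higher number that more compound is needed for the effect), and stand as follows.
- Compound 1 `Cc1c(C)c2c(c(C)c1N)CC(C)(CNc1ccccc1)O2` gives 15.7 mg/kg
- Compound 2 `COC(=O)/C=C\C1(C)Cc2c(C)c(N)c(C)c(C)c2O1` gives > 100 mg/kg as a limit and not a number
- Compound 3 `CNc1c(C)c(C)c2c(c1C)CC(C)(C)O2` gives 16.6 mg/kg

Compound 3 at 16.6 mg/kg and compound 1 at 15.7 mg/kg sit within the scatter of each other, so the two cannot be told apart. Compound 2 reached only a limit of the assay.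

Compound 4 (`Cc1c(C)c2c(c(C)c1Nc1cccnc1)CC(C)(C)O2`) is compound 3 with pyridin-3-yl in place of methyl on a nitrogen on an aromatic ring. Within the data shown here, no two measured compounds differ in one place only, so the size of such a change in this assay has not been seen directly. Starting from compound 3 at 16.6 mg/kg no shift beyond the scatter is expected in either direction. The expected change is a step of a 1.2-fold higher number from compound 3 to compound 4 (0.08 log units; within the scatter) and no more. The upper margin stays wide because of the limit of > 100 mg/kg in this assay, at which 1 of the 3 values shown sits, and what it shows for this small set. In this assay the estimate for compound 4 is 20 mg/kg with an expected range from 6 mg/kg to 70 mg/kg as its upper end.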

Compound 4, dose for 50% inhibition: > 50 mg/kg
Compound 4 gave a limit, no number; the forecaster's own chance of this, stated with the estimate: 15%; middle value at least 2.5-fold (0.39 log units) away from the limit.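

In this assay compound 4 gives > 50 mg/kg, which is a limit of the assay and not a number. Among these compounds, putting pyridin-3-yl in place of methyl on this nitrogen on an aromatic ring gives an at least 3.0-fold higher number from compound 3 to compound 4 (0.47 log units; beyond the scatter), the first change in a single place seen in this set, and it shows that more compound is needed once this larger group sits there. Only the smallest possible size of the step can be read, since the true value of compound 4 lies somewhere past the limit: the limit of > 50 mg/kg in this assay, at which 1 of the 4 values shown sits.

The compounds shown leave open whether the rise belongs to any six-membered aromatic ring on this nitrogen or specifically to the pyridin-3-yl group. They also leave open whether a small group such as ethyl or acetyl in the same place would keep the number close to that of compound 3, at 16.6 mg/kg.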